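Hydrazone aryl variation on a benzothiazole-phenyl hydrazide series

The compounds below may be only part of what the source reports. "The series", "measured", "known", "first", "only" and "open" are said of these compounds alone.

Measured so far:
- compound 1 `O=C(N/N=C\c1ccccn1)c1ccc(-c2nc3ccccc3s2)cc1`: in an assay on isolated protein for inhibition of Maltase-glucoamylase (Homo sapiens), with a stated time of 15 min (a higher number here means a weaker inhibitor, a lower number a stronger inhibitor), compound 1 gives 10200 nM
- compound 2 `O=C(N/N=C/c1ccccc1O)c1ccc(-c2nc3ccccc3s2)cc1`: in this assay compound 2 gives 5550 nM
- compound 3 `O=C(N/N=C/c1ccc(Cl)cc1)c1ccc(-c2nc3ccccc3s2)cc1`: in this assay compound 3 gives 5310 nM

Compound 3 has the lowest number of the three, yet its nearest neighbour compound 2 sits within the scatter (a 1.0-fold lower number from compound 2 to compound 3 (0.02 log units; within the scatter)), as does compound 1 (a 1.9-fold lower number from compound 1 to compound 3 (0.28 log units; within the scatter)), so no ordering is claimed.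

Compound 4 `O=C(N/N=C/c1ccncc1)c1ccc(-c2nc3ccccc3s2)cc1` differs from compound 3 by pyridin-4-yl in place of 4-chlorophenyl on a carbon with a double bond to nitrogen. Among the measured compounds shown here, the steps that bear on it are the exchanges of the aryl group on the same carbon: a 1.9-fold lower number from compound 1 to compound 3 (0.28 log units; within the scatter) and a 1.8-fold lower number from compound 1 to compound 2 (0.26 log units; within the scatter), both within the scatter. Going back toward a pyridyl, a small rise in number, within the scatter, is expected: a 1.5-fold higher number from compound 3 to compound 4 (0.18 log units; within the scatter). Compound 4 is estimated at 8000 nM, range 3500 nM to 18000 nM.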

Compound 4, half-maximal inhibitory concentration: "not active" (no number reported)
For compound 4 the study gives words and no number; the estimate stays without a comparison.
By their numbers in this assay, from the lowest: compounds 3, 2 and 1 (each within the scatter of the next).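

Among the compounds shown here, compound 4 is reported as "not active" in this assay with no number, so no step from compound 3 or the other compounds can be read. The compounds shown leave open how far compound 4 lies from compound 3 on this read-out. No evidence on hand bears on this result.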